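The source may hold more compounds than are shown below. What is called first, only, known or untested is meant among the compounds shown, and "the series" means these compounds.

Working notes on the series. Of the compounds shown here, three sharing one core have been measured in an assay on HL-60 cells for agonist activity at vitamin D3 receptor (Homo sapiens), read by microscopy, with a stated time of 96 h; a higher number here means that more compound is needed for the effect, a lower number that less compound is needed. Compound 1 `C#CCNC(=O)c1ccc(C(CC)(CC)c2ccc(OCC(=O)C(C)(C)C)c(C)c2)n1CC` gives 2200 nM in this assay. Compound 2 `C#CCCOC(=O)c1ccc(C(CC)(CC)c2ccc(OCC(=O)C(C)(C)C)c(C)c2)n1CC` gives 28800 nM. Compound 3 `CCn1c(C(=O)N(C)CC(=O)O)ccc1C(CC)(CC)c1ccc(OCC(=O)C(C)(C)C)c(C)c1` gives 1390 nM. Compound 3 therefore stands at the low end of the set together with compound 1, since a 1.6-fold lower number from compound 1 to compound 3 (0.20 log units; within the scatter), whereas compound 2 sits well apart: a 13-fold higher number from compound 1 to compound 2 (1.12 log units; beyond the scatter) and a 21-fold lower number from compound 2 to compound 3 (1.32 log units; beyond the scatter).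

The next compound, compound 4 `CCn1c(C(=O)Nc2ccc(OC(F)(F)F)cc2)ccc1C(CC)(CC)c1ccc(OCC(=O)C(C)(C)C)c(C)c1`, again changes only the group on the carbonyl carbon: (4-(trifluoromethoxy)phenyl)amino in place of (carboxymethyl)(methyl)amino on a carbonyl carbon. All three measured steps bear on this position. The two amide-bearing compounds, compound 1 and compound 3, are within the scatter of each other, while the ester-bearing compound 2 is set apart by a large step in the unfavourable direction. Going by the values given here, compound 4 keeps an amide, so no step of the size seen toward compound 2 is expected; the new group is larger than either amide substituent seen so far, which leaves the direction open. The expected outcome is a step of a 1.8-fold higher number from compound 3 to compound 4 (0.25 log units; within the scatter), that is, no move beyond the scatter in this assay. Compound 4 is accordingly estimated at 2500 nM, with a range from 500 nM to 12000 nM.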

Compound 4, half-maximal effective concentration: > 50000 nM
Compound 4: a limit, no number; the forecaster's own chance of this, stated with the estimate: 5%; at least 20-fold (1.30 log units) between middle value and limit.
By their numbers in this assay, from the lowest: compounds 3 and 1 (each within the scatter of the next); then compound 2. At a limit, above all of these: compound 4.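

Compound 4 gives a limit of the assay and not a number in this assay: the limit of > 50000 nM in this assay, at which 1 of the 4 values shown sits. Keeping an amide on the carbonyl carbon is thus not enough to hold the number in the range seen so far for amides: exchanging the (carboxymethyl)(methyl)amino group gives an at least 35-fold higher number from compound 3 to compound 4 (1.55 log units; beyond the scatter), and exchanging propargyl on the amide-type nitrogen gives an at least 22-fold higher number from compound 1 to compound 4 (1.35 log units; beyond the scatter). A large unfavourable step at this position is therefore no longer confined to the ester, although against that ester there is only an at least 1.7-fold higher number from compound 2 to compound 4 (0.23 log units; that floor lies within the scatter), so this pair cannot be put in order.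

The compounds shown leave open whether the step belongs to the aromatic ring or to the trifluoromethoxy group, which a plain phenylamino group on the carbonyl carbon would help to separate. Also open, from the compounds shown here alone, is how a benzylamino group or a simple dimethylamino group would read here, and whether the carboxylic acid of compound 3 plays any part in its value, which a matching methyl ester would address.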